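The source may report more compounds than this note shows. Statements on the series, on what has been measured and on what is new or still open speak of the compounds shown alone.

Within the data shown here, in a functional assay on HeLa cells (Homo sapiens) for antiproliferative activity, read by sulforhodamine B assay, with a stated time of 72 h (a lower number here means a stronger inhibitor, a higher number a weaker inhibitor), compound 2 `S=C(N/N=C/c1ccc2ccccc2n1)Nc1cccc(Br)c1` gives 70000 nM, the higher of the two exact numbers measured so far. Compound 3 `NC(=S)N/N=C/c1cc2ccccc2s1` gives 6770 nM, a lower number by a margin well beyond the usual scatter of repeated measurements. Compound 1 `COc1ccc(C)cc1NC(=S)N/N=C/c1ccc2ccccc2n1` has no exact number: its result, > 100000 nM, is a limit of the assay.

The next compound to consider is compound 4 `S=C(N/N=C/c1ccc2ccccc2n1)Nc1ccc(Br)cc1`, which has not yet been measured. It has the same atoms as compound 2, joined differently, with 4-bromophenyl in place of 3-bromophenyl on an amide-type nitrogen. The bromine therefore changes position on the ring, while the counted features of the group stay the same.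

Among the measured compounds shown here, no pair of measured compounds differs in only one place, so the data offer no direct guide to the size of such a step in this assay. The best starting point is the closest measured relative, compound 2 at 70000 nM. The expected step of a 1.4-fold lower number from compound 2 to compound 4 (0.15 log units; within the scatter) is no larger than the scatter, with no firm direction. For compound 4 the estimated value is 50000 nM, with an expected range from 12000 nM to 100000 nM.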

Compound 4, half-maximal inhibitory concentration: 56800 nM
For compound 4 the middle estimate is 1.1-fold (0.06 log units) below the measured one; the measured number falls inside the stated range.
By their numbers in this assay, from the lowest: compound 3; then compounds 4 and 2 (each within the scatter of the next). At a limit, above all of these: compound 1.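

In this assay, putting 4-bromophenyl in place of 3-bromophenyl on the amide-type nitrogen gives a 1.2-fold lower number from compound 2 to compound 4 (0.09 log units; within the scatter). Among these compounds, this is the first comparison here in which only one place changes, and it shows that moving the bromine between these two named groups produces no difference that can be told apart from the ordinary spread of repeated measurements, so neither group can be preferred on this evidence. The assay also has a limit, and compound 1 sits at it: the limit of > 100000 nM in this assay, at which 1 of the 4 values shown sits.

The compounds shown leave open whether any other group on this nitrogen, such as an unsubstituted phenyl, a 4-chlorophenyl or a 4-aminophenyl, would shift the number by more than the scatter. Compound 3 and compound 1 each differ from compound 4 in more than one place, so those comparisons cannot be read as single steps, and no part of the structure can yet be tied to the lower number of compound 3.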